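Side-chain amine changes in a vitamin D3 receptor series

A few compounds are considered here, and "the series" means these few. Any claim that something is new, unique, unknown or untested is made for them only; others in the source may bear on it.

Compound 1: `CCN(CC)CCCNC(=O)c1ccc(C(CC)(CC)c2ccc(OCC(=O)C(C)(C)C)c(C)c2)n1CC`, 22 nM
Compound 2: `CCN(CC)CCNC(=O)c1ccc(C(CC)(CC)c2ccc(OCC(O)C(C)(C)C)c(C)c2)n1CC`, 110 nM
Compound 3: `CCn1c(C(=O)NCCN(C)C)ccc1C(CC)(CC)c1ccc(OCC(O)C(C)(C)C)c(C)c1`, 14 nM

In an assay on HL-60 cells for agonist activity at vitamin D3 receptor (Homo sapiens), read by microscopy, with a stated time of 96 h (on this read-out higher numbers stand for an effect only at larger amounts of compound and lower numbers for an effect already at smaller amounts), compound 3 gives 14 nM, the lowest of the three numbers; compound 1 sits nearest to it, within the scatter, while compound 2 sits furthest, beyond it. Within the data shown here, the one change measured alone in this assay is a 7.9-fold lower number from compound 2 to compound 3 (0.90 log units; beyond the scatter), a modest step. Compound 4, `CCN(CC)CCCNC(=O)c1ccc(C(CC)(CC)c2ccc(OCC(O)C(C)(C)C)c(C)c2)n1CC`, is still unmeasured. It arises from compound 3 by (diethylamino)methyl in place of dimethylamino on a saturated chain carbon, two bonds along the chain from an amide-type nitrogen. Among the measured compounds shown here, no measured step matches this change exactly. Compound 1 carries the same diethylamino group on the same three-carbon chain as compound 4 and differs from it only in the ketone against the hydroxyl of the side chain. In this assay compound 1 gives 22 nM, which lies within the scatter of compound 3. Compound 2, with the shorter chain, was weaker. The expected step is therefore small, a 2.1-fold higher number from compound 3 to compound 4 (0.33 log units; beyond the scatter), probably within the scatter. Compound 4 is estimated at 30 nM, between 10 nM and 100 nM.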

Compound 4, half-maximal effective concentration: 66 nM
Beside the measured number, compound 4's estimate is 2.2-fold (0.34 log units) below it, within the range that was stated.
By their numbers in this assay, from the lowest: compounds 3 and 1 (each within the scatter of the next); then compounds 4 and 2 (each within the scatter of the next).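

In this assay, the step of a 4.7-fold higher number from compound 3 to compound 4 (0.67 log units; beyond the scatter) shows that swapping 2-(dimethylamino)ethyl for 3-(diethylamino)propyl on the amide nitrogen can move the number beyond the scatter. With the diethylamino end kept, the longer chain gives a 1.7-fold lower number from compound 2 to compound 4 (0.22 log units; within the scatter), so among these compounds chain length alone produces no change that can be told from the scatter. The far side of the molecule also counts: 1-hydroxy-2,2-dimethylpropyl in place of (tert-butyl)carbonyl gives a 3.0-fold higher number from compound 1 to compound 4 (0.48 log units; beyond the scatter), so a change away from the amine can shift the number as well.

Nothing available here explains any of these steps. Still open, from the compounds shown here alone, is how 3-(dimethylamino)propyl would behave, which would separate the chain from the amine ends, and whether a ring amine such as pyrrolidine or morpholine at the chain end would fit this series.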